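The compounds below may be only part of what the source reports. "The series", "measured", "known", "first", "only" and "open" are said of these compounds alone.

Three compounds sharing one core were tested in a functional assay on HL-60 cells (Homo sapiens) for antiproliferative activity, read by sulforhodamine B assay, with a stated time of 72 h; a lower number here means a stronger inhibitor, a higher number a weaker inhibitor. Compound 1 `COc1cccc(NC(=S)N/N=C/c2ccc3ccccc3n2)c1` gives 71200 nM in this assay. Compound 2 `S=C(N/N=C/c1ccc2ccccc2n1)Nc1cccc(Br)c1` gives 53800 nM, and the step between them is a 1.3-fold lower number from compound 1 to compound 2 (0.12 log units; within the scatter). Compound 3 `Cc1cccc(NC(=S)N/N=C/c2ccc3ccccc3n2)c1` reaches only a limit of the assay, > 100000 nM, a bound rather than a number (the limit of > 100000 nM in this assay, at which 1 of the 3 values shown sits). Against the two others, compound 3 stands at that bound: an at least 1.4-fold higher number from compound 1 to compound 3 (0.14 log units; that floor lies within the scatter) and an at least 1.8-fold higher number from compound 2 to compound 3 (0.26 log units; that floor lies within the scatter).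

Compound 4 `Fc1ccc(NC(=S)N/N=C/c2ccc3ccccc3n2)cc1` has not been measured. It differs from compound 3 by 4-fluorophenyl in place of 3-methylphenyl on an amide-type nitrogen. The measured steps that bear on this change are the three exchanges of one group on an aromatic carbon, a 1.3-fold lower number from compound 1 to compound 2 (0.12 log units; within the scatter), an at least 1.4-fold higher number from compound 1 to compound 3 (0.14 log units; that floor lies within the scatter) and an at least 1.8-fold higher number from compound 2 to compound 3 (0.26 log units; that floor lies within the scatter), none of which reaches beyond the scatter. It is therefore expected that an at least 1.1-fold lower number from compound 3 to compound 4 (0.07 log units; that floor lies within the scatter) stays within the scatter, with no clear direction. Compound 4 is expected to give about 85000 nM in this assay, between 40000 nM and 180000 nM, with a fair chance that only a limit is reported again.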

Compound 4, half-maximal inhibitory concentration: 17000 nM
Compound 4: the middle estimate sits 5.0-fold (0.70 log units) above what was measured, and the stated range ends above it.
By their numbers in this assay, from the lowest: compound 4; then compounds 2 and 1 (each within the scatter of the next). At a limit, above all of these: compound 3.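

Replacing the aryl group on the amide-type nitrogen can move the number beyond the scatter, which no exchange among compound 1, compound 2 and compound 3 had done: in this assay there is a 3.2-fold lower number from compound 2 to compound 4 (0.50 log units; beyond the scatter) and a 4.2-fold lower number from compound 1 to compound 4 (0.62 log units; beyond the scatter). Compound 3 stands at a limit of the assay and not at a number, so an at least 5.8-fold lower number from compound 3 to compound 4 (0.76 log units; beyond the scatter) is only a floor: the limit of > 100000 nM in this assay, at which 1 of the 4 values shown sits. Compound 4 is the strongest of the four shown in this assay, with its steps to all three others printed as beyond the scatter.

The change replaces both the group and the number in its name, so the compounds shown leave open whether the lower number goes with fluorine or with the 4-substituted phenyl. A 3-fluorophenyl or a 4-bromophenyl group on the same nitrogen would separate the two.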